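The compounds below may be only part of what the source reports. "The series", "measured", "known", "first", "only" and "open" are said of these compounds alone.

Compound 1 `CC(C(=O)N1CCN(c2ccccc2)CC1)N1C(=O)CCC1=O` stands highest of the two numbers measured in a functional assay on the whole organism (strain Swiss) with Mus musculus as the target, in the maximal electroshock model, with a stated time of 1 h, at a dose of 300 mg/kg by the intraperitoneal route; a lower number here means a weaker effect, a higher number a stronger effect of the compound at the dose given: compound 1 gives 50%, while compound 2 `Cc1cccc(N2CCN(C(=O)C(C)N3C(=O)CCC3=O)CC2)c1` gives 0%, a change of a number 50 percentage points lower from compound 1 to compound 2 (beyond the scatter). Compound 3 `CCC(C(=O)N1CCN(c2ccccc2)CC1)N1C(=O)CCC1=O` differs from compound 1 by methyl in place of hydrogen on a saturated chain carbon, two bonds along the chain from an amide-type nitrogen in a ring and a carbonyl carbon. Among the measured compounds shown here, no measured step touches this chain position; the only known step concerns an aromatic carbon, so it bears little on this change. The step is therefore expected to stay within the scatter, a number 5 percentage points lower from compound 1 to compound 3 (within the scatter). Compound 3 is estimated at 45%, within 10% to 80%.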

Compound 3, a percentage reported as activity, at one dose (the size of the read-out at that dose, not a potency): 75%
Compound 3: the middle estimate sits 30 percentage points below what was measured, and the stated range covers the measured number.
By their numbers in this assay, from the lowest: compound 2; then compound 1; then compound 3.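

In this assay, the saturated chain carbon proves responsive to substitution, with a number 25 percentage points higher from compound 1 to compound 3 (beyond the scatter) for methyl in place of hydrogen. The same exchange runs the opposite way on the aromatic carbon, with a number 50 percentage points lower from compound 1 to compound 2 (beyond the scatter) for that step, so the direction of the methyl effect depends on where it sits on the core of compound 1. Nothing available explains this rise. As far as these compounds go, whether a longer chain such as propyl at this carbon would extend the rise remains open. So does whether a cyclopropyl ring would be accepted there.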